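A few compounds are considered here, and "the series" means these few. Any claim that something is new, unique, unknown or untested is made for them only; others in the source may bear on it.

Measured compounds:
- compound 1 `COc1ccc(-c2csc(NC(=O)[C@H](CCCCNS(N)(=O)=O)NC(=O)OCc3ccccc3)n2)cc1`, which in an assay for inhibition of protein deacetylase HDAC6 (Homo sapiens) (on this read-out lower numbers stand for stronger inhibition and higher numbers for weaker inhibition), gives 200 nM
- compound 2 `NS(=O)(=O)NCCCC[C@H](NC(=O)OCc1ccccc1)C(=O)Nc1nc(-c2ccc(Cl)cc2)cs1`, which in this assay gives 250 nM
- compound 3 `NS(=O)(=O)NCCCC[C@H](NC(=O)OCc1ccc(Cl)cc1)C(=O)Nc1nc(-c2ccccc2)cs1`, which in this assay gives 530 nM

Compound 3 stands at the highest of the three numbers, beyond the scatter from both others. Compound 4 `CCOC(=O)N[C@@H](CCCCNS(N)(=O)=O)C(=O)Nc1nc(-c2ccccc2)cs1` differs from compound 3 by methyl in place of 4-chlorophenyl on a saturated chain carbon bound to an oxygen next to a carbonyl group; the carbamate thus shrinks from a ((4-chlorobenzyl)oxy)carbonyl to an ethoxycarbonyl. Going by the values given here, no measured step touches this part of the molecule: the only one, a 1.3-fold higher number from compound 1 to compound 2 (0.10 log units; within the scatter), swaps a group on the other aromatic ring and stays within the scatter. The expectation for compound 4 therefore rests on little, and a weakening step a 2.3-fold higher number from compound 3 to compound 4 (0.35 log units; beyond the scatter) in this assay is estimated, with wide uncertainty. Compound 4 is expected to give about 1200 nM, somewhere between 350 nM and 4500 nM.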

Compound 4, half-maximal inhibitory concentration: 200 nM
The estimate for compound 4 lay 6.0-fold (0.78 log units) above the measured number; measured number below the stated range.
By their numbers in this assay, from the lowest: compounds 1, 4 and 2 (each within the scatter of the next); then compound 3.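

In this assay, methyl in place of 4-chlorophenyl on the saturated chain carbon bound to an oxygen next to a carbonyl group gives a 2.7-fold lower number from compound 3 to compound 4 (0.42 log units; beyond the scatter), so this end of the molecule does affect the read-out. The 4-chlorophenyl ring is also not needed here for inhibition, since the much smaller ethoxycarbonyl group gives the lower number. Nothing available explains this difference. Still open, as far as these compounds go, is whether the chlorine or the aromatic ring accounts for the step, and how a plain benzyl group, a longer chain such as butyl, or an amine would read at this place.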